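This account rests on a few compounds, and the source may have more. Where it says the series, first, only, none or still open, it means among the compounds named here.

Measured in a functional assay on HeLa cells (Homo sapiens) for antiproliferative activity, read by MTT assay, with a stated time of 72 h; a lower number here means a stronger inhibitor, a higher number a weaker inhibitor:
compound 1 `Cc1ccc(-c2c(CN3CCCCC3)nc3scc(C(=O)O)n23)cc1`: 7630 nM
compound 2 `CCC(=O)NNC(=O)c1csc2ncc(-c3ccc(C)cc3)n12`: 13000 nM
compound 3 `CCCC(=O)NNC(=O)c1csc2ncc(-c3ccc(C)cc3)n12`: 45600 nM

Among these three, compound 3 has the highest number, at 45600 nM, and so is the weakest inhibitor of the set. Its nearest neighbour is compound 2, and the chain change linking them is a 3.5-fold higher number from compound 2 to compound 3 (0.55 log units; beyond the scatter). Compound 1 lies further off, with its value the lowest of the three.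

Compound 4 `CCCC(=O)NNC(=O)c1csc2ncc(-c3ccc(Br)cc3)n12` keeps the chain of compound 3 and changes the other end of the molecule: bromo in place of methyl on an aromatic carbon. In words, bromo replaces methyl on an aromatic carbon, turning 4-methylphenyl into 4-bromophenyl.

Among the compounds with values here, only one measured step exists, a 3.5-fold higher number from compound 2 to compound 3 (0.55 log units; beyond the scatter), and it lies on the saturated chain rather than on the aromatic ring. It therefore gives a rough idea of size but no direction. Within the data shown here, no measured compound carries the bromo group, so the data hold no direct precedent. In this assay, a modest shift at most is expected, leaning towards a lower number only in that compound 3 sits at the top of the range. The estimated step is a 1.6-fold lower number from compound 3 to compound 4 (0.21 log units; within the scatter). For compound 4 the expected value is 28000 nM, with an estimated range from 9000 nM to 80000 nM.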

Compound 4, half-maximal inhibitory concentration: 31900 nM
The estimate for compound 4 lay 1.1-fold (0.06 log units) below the measured number; the measured number falls inside the stated range.
By their numbers in this assay, from the lowest: compounds 1 and 2 (each within the scatter of the next); then compounds 4 and 3 (each within the scatter of the next).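

At the aromatic end of the molecule, the only step shown on this ring is a 1.4-fold lower number from compound 3 to compound 4 (0.16 log units; within the scatter) in this assay, so with the chain of compound 3 held fixed, 4-methylphenyl and 4-bromophenyl cannot be told apart in this read-out. The earlier compounds offered only a step on the saturated chain, a 3.5-fold higher number from compound 2 to compound 3 (0.55 log units; beyond the scatter), which lies beyond the scatter, whereas this exchange of methyl for bromo on an aromatic carbon stays within it; among the compounds shown, the one measurable change therefore sits on the chain and not at this ring position. No measurement is available that would explain why this exchange leaves the number within the scatter.

The compounds shown leave open whether a different group on this aromatic carbon, such as a methoxy group, a nitrile or an amine, would move the number beyond the scatter, given that only methyl and bromo can be compared here. They also leave open whether the chain step seen with 4-methylphenyl would recur with 4-bromophenyl, and what a longer chain would do with either ring.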